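From two double bonds to a saturated chain

A few compounds are considered here, and "the series" means these few. Any claim that something is new, unique, unknown or untested is made for them only; others in the source may bear on it.

Measured in a functional assay on MCF7 cells (Homo sapiens) for antiproliferative activity, read by MTT assay; a lower number here means a stronger inhibitor, a higher number a weaker inhibitor:
compound 1 `CCCC/C=C\CCCCCCCCCc1cc(=O)c2c(O)cc(OCOC)c(C)c2o1`: > 67200 nM
compound 2 `CCCCCCCCCCCCCCCc1cc(=O)c2c(O)cc(O)c(C)c2o1`: 17500 nM
compound 3 `CCCCC/C=C\C/C=C\CCCCCCCc1cc(=O)c2c(O)cc(OCOC)c(C)c2o1`: > 84100 nM

Compound 3 has no exact number in this assay and stands only at a limit of > 84100 nM. Compound 1 likewise gives only a limit, > 67200 nM. Compound 2 alone has a measured number, 17500 nM.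

Compound 4 `CCCCCCCCCCCCCCCc1cc(=O)c2c(O)cc(OCOC)c(C)c2o1` is still to be measured. It differs from compound 3 in one place: octyl in place of deca-1,4-dien-1-yl on a saturated chain carbon, seven bonds along the chain from an aromatic carbon. Among the compounds with values here, the only measured step that bears on this change, a step that the two limits leave unreadable from compound 1 to compound 3, alters the chain at the same place, but it gives no size to carry over. Compound 4 is therefore expected to stay weak in this assay, with no step beyond the scatter, and a further limit would be no surprise. This expectation rests on compound 3, with its limit of > 84100 nM. The expected change is an at least 1.2-fold lower number from compound 3 to compound 4 (0.07 log units; that floor lies within the scatter). For compound 4 the estimated value is 70000 nM, within an expected range of 30000 nM to 120000 nM.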

Compound 4, half-maximal inhibitory concentration: > 67200 nM
Compound 4 ended at the assay's limit (the forecaster's own chance of this, stated with the estimate: 70%); the middle value lies beyond the limit too.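

In this assay compound 4 gives > 67200 nM, which is a limit and not a number. Within the data shown here, with the saturated chain held the same, methoxymethyl in place of hydrogen on an oxygen on an aromatic ring gives an at least 3.8-fold higher number from compound 2 to compound 4 (0.58 log units; beyond the scatter), the first readable step, and it shows that this change on the oxygen weakens the compound beyond the scatter. The steps that change the chain have limits at both ends and cannot be read, so removing the double bonds shows no measurable effect here.

On these data alone, how the chains compare when methoxymethyl is present therefore stays open. Also open, as far as these compounds go, is whether the double bonds, a shorter chain or a carboxylic acid at the chain end would alter the activity when hydrogen stands on that oxygen.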